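The compounds below may be only part of what the source reports. "The series", "measured", "known", "first", "only" and "open" are said of these compounds alone.

Measured so far:
compound 1 `COCCCn1c(CN2C(=O)/C(=N/OCc3ccncc3)c3ccccc32)nc2ccccc21`: 0.01 h
compound 2 `COC(=O)c1ccc(CO/N=C2/C(=O)N(Cc3nc4ccccc4n3CCC(C)C)c3ccccc32)cc1`: 0.01 h

In an ADME assay on liver (Homo sapiens) for metabolic stability (on this read-out higher numbers stand for a longer-lived compound and lower numbers for a shorter-lived compound), compound 1 gives 0.01 h, and compound 2 gives 0.01 h, so the two stand level at the digits reported. Compound 3 `COCCCn1c(CN2C(=O)/C(=N/OC)c3ccccc32)nc2ccccc21` is still unmeasured. It keeps the core of compound 1 and differs in one place: hydrogen in place of pyridin-4-yl on a saturated chain carbon bound to an oxygen. That is hydrogen in place of pyridin-4-yl on a saturated chain carbon bound to an oxygen, so (pyridin-4-yl)methoxy becomes methoxy. For the measured compounds named here, no measured step bears on this change, so the expectation is loose. A small rise in half-life is expected, though a result within the scatter would not surprise. Compound 1 stands at 0.01 h. That leaves little room downward. The expected step is a 3.0-fold higher number from compound 1 to compound 3 (0.48 log units; beyond the scatter). Compound 3 is estimated at 0.03 h, with an expected range of 0.01 h to 0.15 h.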

Compound 3, half-life: 0.267 h
Compound 3: the middle estimate sits 8.9-fold (0.95 log units) below what was measured, outside the stated range (above it).
By their numbers in this assay, from the lowest: compounds 1 and 2 (each within the scatter of the next); then compound 3.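

In this assay, hydrogen in place of pyridin-4-yl on a saturated chain carbon bound to an oxygen, which turns (pyridin-4-yl)methoxy into methoxy, gives a 27-fold higher number from compound 1 to compound 3 (1.43 log units; beyond the scatter), so this position can move the half-life by a large step. Compound 1 and compound 2 differ in more than one place and could not single out any position, whereas here the rest of the core of compound 1 stays the same and the step belongs to this one change. Nothing in hand gives a reason for the step.

The compounds shown cover only the two ends of this change, so it remains open whether the step follows the loss of the pyridin-4-yl ring or the shorter group on the oxygen. A plain benzyl or an ethyl group on the same oxygen would separate these two readings.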